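A Butyl Group in Place of 4-Methoxyphenyl

This account rests on a few compounds, and the source may have more. Where it says the series, first, only, none or still open, it means among the compounds named here.

In a functional assay on HeLa cells (Homo sapiens) for antiproliferative activity, read by sulforhodamine B assay, with a stated time of 48 h (a lower number here means a stronger inhibitor of growth, a higher number a weaker inhibitor of growth), compound 1 `Cc1ccc(-c2cn(CCCN3C(=O)COc4ccccc43)nn2)cc1` gives 14300 nM and compound 2 `COc1ccc(-c2cn(CCCN3C(=O)COc4ccccc43)nn2)cc1` gives 4900 nM while compound 3 `O=C1COc2ccccc2N1CCCn1cc(-c2ccccn2)nn1` gives 10000 nM on the same core. Compound 2 stands lowest of the three, as shown by a 2.9-fold lower number from compound 1 to compound 2 (0.47 log units; beyond the scatter) and by a 2.0-fold higher number from compound 2 to compound 3 (0.31 log units; beyond the scatter) in the two steps that reach it. The third step (a 1.4-fold lower number from compound 1 to compound 3 (0.16 log units; within the scatter)) stays within the scatter.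

Compound 4 `CCCCc1cn(CCCN2C(=O)COc3ccccc32)nn1` has not yet been measured. It has butyl in place of 4-methoxyphenyl on an aromatic carbon and so keeps the core of compound 1.

Within the data shown here, no measured step replaces an aromatic group with an open chain, so none matches this change directly. The nearest guide is compound 3, the only other case where 4-methoxyphenyl is replaced, and that modest step (a 2.0-fold higher number from compound 2 to compound 3 (0.31 log units; beyond the scatter)) goes to a higher number. Compound 1, at 14300 nM with no methoxy group, also stands higher. On that basis a modest rise is expected, estimated as a 2.7-fold higher number from compound 2 to compound 4 (0.42 log units; beyond the scatter) in this assay with wide uncertainty. Compound 4 is expected in this assay at 13000 nM within a range of 5000 nM to 35000 nM as estimated here.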

Compound 4, concentration for 50% growth inhibition: 1020 nM
Beside the measured number, compound 4's estimate is 13-fold (1.11 log units) above it, outside the stated range (below it).
By their numbers in this assay, from the lowest: compound 4; then compound 2; then compounds 3 and 1 (each within the scatter of the next).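

The result shows that an aromatic group is not required at this position, on the five-membered aromatic ring with 3 nitrogen: in this assay butyl, which has no ring, gives a 4.8-fold lower number from compound 2 to compound 4 (0.68 log units; beyond the scatter) and goes further still against the other two aromatic groups, with a 9.8-fold lower number from compound 3 to compound 4 (0.99 log units; beyond the scatter) and a 14-fold lower number from compound 1 to compound 4 (1.15 log units; beyond the scatter) as the remaining steps. Among these compounds, the largest step among the aromatic groups had been a 2.9-fold lower number from compound 1 to compound 2 (0.47 log units; beyond the scatter), so those compounds gave no sign of a number as low as the one compound 4 reaches, 1020 nM, and all three aromatic groups now stand on the higher side of the open chain. No measurement available here accounts for this gain.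

With only one open chain among the compounds shown, it remains open how the number moves with a propyl or hexyl chain, a branched chain such as isobutyl, or a saturated ring such as cyclohexyl. Also open, as far as these compounds go, is whether a chain ending in an amine or a carboxylic acid would keep the low number of compound 4.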